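From pyridin-2-yl to pyridin-4-yl on a thiophene-bearing compound

The source may hold more compounds than are shown below. What is called first, only, known or untested is meant among the compounds shown, and "the series" means these compounds.

In a functional assay on SK-OV-3 cells (Homo sapiens) for antiproliferative activity (on this read-out lower numbers stand for stronger inhibition of growth and higher numbers for weaker inhibition of growth), compound 3 (`c1ccc(-c2cc(-c3cccs3)cc(-c3ccccn3)n2)nc1`) gives 0.12 ug/mL and stands level with compound 1 (`c1ccc(-c2cc(-c3ccccn3)nc(-c3ccccn3)c2)cc1`) at 0.12 ug/mL as the lowest pair, while compound 2 (`c1ccc(-c2cc(-c3ccoc3)cc(-c3ccccn3)n2)nc1`) gives a higher 0.6 ug/mL in this set. Thiophen-2-yl in place of phenyl left the number unmoved (no change at the digits printed from compound 1 to compound 3 (within the scatter)). Furan-3-yl moved it (a 5.0-fold higher number from compound 1 to compound 2 (0.70 log units; beyond the scatter)), and thiophen-2-yl restored it (a 5.0-fold lower number from compound 2 to compound 3 (0.70 log units; beyond the scatter)). Compound 4 (`c1ccc(-c2cc(-c3cccs3)cc(-c3ccncc3)n2)nc1`) carries pyridin-4-yl in place of pyridin-2-yl on an aromatic carbon. Going by the values given here, no measured step changes a pyridine ring, so these steps only suggest a modest scale, and the direction is a cautious guess. The expected change is a modest rise (a 2.9-fold higher number from compound 3 to compound 4 (0.46 log units; beyond the scatter)). The estimate for compound 4 is 0.35 ug/mL (range 0.1 ug/mL to 1.5 ug/mL).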

Compound 4, concentration for 50% growth inhibition: 48.3 ug/mL
Compound 4: middle estimate off by 140-fold (2.14 log units), on the low side, outside the stated range (above it).
By their numbers in this assay, from the lowest: compounds 1 and 3 (each within the scatter of the next); then compound 2; then compound 4.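

In this assay, exchanging pyridin-2-yl for pyridin-4-yl, with the same atoms joined differently, gives a 400-fold higher number from compound 3 to compound 4 (2.60 log units; beyond the scatter) and outweighs every earlier step among phenyl, furan-3-yl and thiophen-2-yl. The number at this place, next to the ring nitrogen, thus depends strongly on where the nitrogen of the attached ring lies, even though the group's atoms and counts stay the same. No available evidence accounts for this step.

The compounds shown leave open whether pyridin-3-yl here would fall nearer compound 3 or compound 4. They also leave open whether an amine on the pyridin-4-yl ring would recover any of the lost growth inhibition.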